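The compounds below may be only part of what the source reports. "The series", "measured", "known", "first", "only" and "open" are said of these compounds alone.

Values in a functional assay on 1A9 cells (Homo sapiens); on this read-out higher numbers stand for an effect only at larger amounts of compound and lower numbers for an effect already at smaller amounts:
- compound 1 `COc1cc2nc(-c3cccc(F)c3)nc(O)c2cc1OC`: > 20 ug/mL, a limit of the assay
- compound 2 `COc1cccc(-c2nc(O)c3ccccc3n2)c1`: "not active" (no number reported)
- compound 3 `COc1cccc(-c2nc(O)c3cc(OC)ccc3n2)c1`: 4.7 ug/mL

Within the data shown here, compound 3 gives the only actual number, 4.7 ug/mL. Compound 4 `COc1cccc(-c2nc(O)c3cc(OC)c(OC)cc3n2)c1` carries methoxy in place of hydrogen on an aromatic carbon of the core of compound 3, ortho to a methoxy group: methoxy in place of hydrogen on an aromatic carbon. Among the measured compounds shown here, no measured pair isolates this change. Compound 4 has the same core as compound 1. Compound 1 gives only the limit > 20 ug/mL. On that basis, a moderate loss toward higher numbers in this assay is expected, a 1.9-fold higher number from compound 3 to compound 4 (0.28 log units; within the scatter). For compound 4 the estimated value is 9 ug/mL, with an expected range of 3 ug/mL to 25 ug/mL.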

Compound 4, concentration for half-maximal effect: 17.5 ug/mL
For compound 4 the middle estimate is 1.9-fold (0.29 log units) below the measured one; the range from low to high includes it.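

In this assay, among these compounds, methoxy in place of hydrogen, ortho to a methoxy group on the core, gives a 3.7-fold higher number from compound 3 to compound 4 (0.57 log units; beyond the scatter), the first numerical step: at this position, the added methoxy moves the effect to larger amounts of compound. Methoxy in place of fluoro on an aromatic carbon gives an at least 1.1-fold lower number from compound 1 to compound 4 (0.05 log units; that floor lies within the scatter), a step that rests on a limit of the assay: the limit of > 20 ug/mL in this assay, at which 1 of the 4 values shown sits.

From the compounds shown here alone, whether an amine or an ethoxy group at this position would behave like methoxy stays open. Going by these compounds, the true size of the fluoro exchange also stays open.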